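A few compounds are considered here, and "the series" means these few. Any claim that something is new, unique, unknown or untested is made for them only; others in the source may bear on it.

Three compounds have been measured in a functional assay on HT-29 cells (Homo sapiens) for cytotoxicity, read by MTT assay, with a stated time of 24 h, tested at 1.6 ug/mL; on this read-out lower numbers stand for a weaker effect and higher numbers for a stronger effect at the one concentration tested:

compound 1, `Cn1c(-c2ccc(NC(=O)CSc3nc4ccccc4o3)cc2)nc(-c2ccccc2)c1-c1ccccc1`, gives 41%
compound 2, `Cn1c(-c2ccc(NC(=O)CSC3=NCCS3)cc2)nc(-c2ccccc2)c1-c1ccccc1`, gives 30.4%
compound 3, `CN1CCN(CC(=O)Nc2ccc(-c3nc(-c4ccccc4)c(-c4ccccc4)n3C)cc2)CC1`, gives 27.4%

Compound 3 stands lowest of the three numbers in this assay. Its nearest neighbour is compound 2, separated by a number 3 percentage points lower from compound 2 to compound 3 (within the scatter), and its furthest is compound 1, separated by a number 13.6 percentage points lower from compound 1 to compound 3 (beyond the scatter). Compound 4, `CN(C)/C=C/N1CCN(CC(=O)Nc2ccc(-c3nc(-c4ccccc4)c(-c4ccccc4)n3C)cc2)CC1`, has not yet been measured. It differs from compound 3 by 2-(dimethylamino)ethenyl in place of methyl on an amine nitrogen in a ring.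

The two steps that lead to compound 3, a number 13.6 percentage points lower from compound 1 to compound 3 (beyond the scatter) and a number 3 percentage points lower from compound 2 to compound 3 (within the scatter), each exchange the whole 4-methylpiperazin-1-yl for a different group on the saturated chain carbon bound to the carbonyl carbon, and neither touches the amine nitrogen in the ring. Among the measured compounds shown here, no measured step therefore bears directly on the change to compound 4, and the available steps only show that this part of the molecule moves the read-out by modest amounts at most. Compound 4 is expected to give 28% in this assay, within 15% to 42%. The expected step of a number 0.6 percentage points higher from compound 3 to compound 4 (within the scatter) would lie within the scatter.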

Compound 4, a percentage reported as activity, at one concentration (the size of the read-out at that concentration, not a potency): 8%
Beside the measured number, compound 4's estimate is 20 percentage points above it; measured number outside the range, below it.
By their numbers in this assay, from the lowest: compound 4; then compounds 3 and 2 (each within the scatter of the next); then compound 1.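

In this assay, among the compounds shown here, the amine nitrogen in the ring proves to be a sensitive place: 2-(dimethylamino)ethenyl in place of methyl there gives a number 19.4 percentage points lower from compound 3 to compound 4 (beyond the scatter) and is larger than any step among the earlier compounds. The same group also sets compound 4 clearly apart from the other two compounds, with a number 22.4 percentage points lower from compound 2 to compound 4 (beyond the scatter) and a number 33 percentage points lower from compound 1 to compound 4 (beyond the scatter) on exchange of the whole group on the saturated chain carbon bound to the carbonyl carbon, so that compound 4 shows the weakest effect of the four at the one concentration tested. Nothing available accounts for this drop.

The compounds shown leave open which part of the entering group goes with the lower number. A saturated 2-(dimethylamino)ethyl chain or a plain ethyl on the same nitrogen would separate the double bond from the added amine.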